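The Nitrile Analogue and a Ceiling of Limits

The compounds below may be only part of what the source reports. "The series", "measured", "known", "first", "only" and "open" are said of these compounds alone.

Of the compounds shown here, three with a shared core have been measured. Compound 1 `CC1CCN(C2CCN(S(=O)(=O)c3ccc(C(C)C)cc3)CC2)CC1` in an ADME assay on HCT-116 cells (Homo sapiens) for cytotoxicity, read by CellTiter-Glo, with a stated time of 72 h (on this read-out higher numbers stand for weaker inhibition and lower numbers for stronger inhibition), gives > 5000 nM, which is a limit of the assay and not a number. Compound 2 `Cc1ccc(S(=O)(=O)N2CCC(N3CCC(C)CC3)CC2)cc1C` likewise reaches only a limit, > 5000 nM. Compound 3 `Cc1cccc(S(=O)(=O)N2CCC(N3CCC(C)CC3)CC2)c1` stands at a limit as well, > 5000 nM. Going by the values given here, the one step that can be drawn, a step that the two limits leave unreadable from compound 2 to compound 3, has no readable size, since both ends are limits; indeed (the limit of > 5000 nM in this assay, at which 3 of the 3 values shown sit). Compound 4 `CC1CCN(C2CCN(S(=O)(=O)c3ccc(C#N)cc3)CC2)CC1` has not yet been measured. It differs from compound 3 by 4-cyanophenyl in place of 3-methylphenyl on a sulfonyl sulfur. Among the compounds with values here, no measured step speaks to a 4-cyanophenyl group, and the single step that exists cannot be read. The expectation for compound 4 therefore rests only on the ceiling at which its neighbours sit. The step that the limit leaves unreadable from compound 3 to compound 4 is estimated to be none beyond the scatter. Compound 4 is expected to come out near 8000 nM, within a range from 3000 nM to 30000 nM, most likely as another limit.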

Compound 4, half-maximal inhibitory concentration: > 5000 nM
Compound 4 was reported as a limit; the forecaster's own chance of this, stated with the estimate: 80%; the middle value does not contradict the limit.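

Compound 4 sits at a limit of the assay, as do compound 1, compound 2 and compound 3, so the steps to compound 4 cannot be read: the limit of > 5000 nM in this assay, at which 4 of the 4 values shown sit.

The compounds shown leave open what true value any of them has in this assay, and whether any group on the sulfonyl sulfur would give a measurable one.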